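A few compounds are considered here, and "the series" means these few. Any claim that something is new, unique, unknown or untested is made for them only; others in the source may bear on it.

Compound 1 `C[Se]/C(=N\C(=O)c1ccco1)NC(=O)c1ccco1`: in a functional assay on HT-29 cells (Homo sapiens) for cytotoxicity, read by MTT assay, with a stated time of 72 h (on this read-out higher numbers stand for weaker inhibition of growth and lower numbers for stronger inhibition of growth), compound 1 gives > 100000 nM, a limit of the assay rather than a number.
Compound 2 `O=C(/N=C(/NC(=O)c1ccco1)[Se]Cc1ccccc1)c1ccco1`: in this assay compound 2 gives 89100 nM.
Compound 3 `O=C(/N=C(/NC(=O)c1csc([N+](=O)[O-])c1)[Se]Cc1ccccc1)c1csc([N+](=O)[O-])c1`: in this assay compound 3 gives > 100000 nM, also a limit rather than a number.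

Compound 1 differs from compound 2 by hydrogen in place of phenyl on a saturated chain carbon bound to a selenium atom. That change produced an at least 1.1-fold higher number from compound 2 to compound 1 (0.05 log units; that floor lies within the scatter), so the two sit within the usual scatter of each other. The difference between the core of compound 3 and the core of compound 2 is not broken down here. Compound 4 `C[Se]/C(=N\C(=O)c1csc([N+](=O)[O-])c1)NC(=O)c1csc([N+](=O)[O-])c1` has not been measured; it differs from compound 3 by hydrogen in place of phenyl on a saturated chain carbon bound to a selenium atom, the same change at the same place. Because compound 3 already sits at the limit of > 100000 nM in this assay, at which 2 of the 3 values shown sit, and the earlier step stayed small, compound 4 is expected to remain at that limit as well, an expected step that the limit leaves unreadable from compound 3 to compound 4. Compound 4 is therefore estimated in this assay at 150000 nM, with a range from 80000 nM to 400000 nM.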

Compound 4, concentration for total growth inhibition: > 100000 nM
Compound 4: only a limit was reported; the forecaster's own chance of this, stated with the estimate: 85%; the middle value lies beyond the limit too.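

No step can be read from compound 3 to compound 4, as each gives a limit of the assay rather than a number: the limit of > 100000 nM in this assay, at which 3 of the 4 values shown sit.
The compounds shown leave open what numbers compound 3 and compound 4 would actually give, and so whether going from benzyl to methyl changes anything on their shared core.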